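The source may hold more compounds than are shown below. What is called first, only, known or untested is meant among the compounds shown, and "the series" means these compounds.

Measured compounds:

Compound 1, `C=CCONC(=O)CN1C(=O)S/C(=C\c2ccc(C(=O)N[C@H](C(=O)OC)C(C)C)cc2)C1=O`: > 128000 nM
Compound 2, `C=CCONC(=O)Cn1ccc(C(=O)NCC(=O)N[C@@H](CC(C)C)C(=O)O)c1`: > 128000 nM
Compound 3, `C=CCONC(=O)Cn1ccc(C(=O)N[C@@H](C)C(=O)N[C@H](C(=O)O)C(C)C)c1`: > 128000 nM

All three entries come from a functional assay on MRC5 cells (Homo sapiens) for inhibition, read by microscopy and resazurin assay, with a stated time of 72 h; on this read-out higher numbers stand for weaker inhibition and lower numbers for stronger inhibition. None of them is a number; each is a limit of the assay, the highest concentration tested, and the compound did nothing measurable up to it: the limit of > 128000 nM in this assay, at which 3 of the 3 values shown sit. Compound 3 therefore stands at that limit and nowhere more precise. For the measured compounds named here, compound 1 and compound 2 stand at the same limit, so nothing in these numbers separates the three compounds from one another, and no step between any pair of them can be given.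

Compound 4, `C=CCONC(=O)Cn1ccc(C(=O)N[C@@H](C)C(=O)N[C@@H](CC(C)C)C(=O)O)c1`, differs from compound 3 in one place: isobutyl in place of isopropyl on a saturated chain carbon bound to an amide-type nitrogen and a carbonyl carbon. The same isobutyl side chain next to a free carboxylic acid is already present in compound 2, and compound 2 sits at the limit. With compound 3 itself at the limit, the step to compound 4 is expected to be none beyond the scatter, meaning that the change from compound 3 to compound 4 is estimated as a step that the limit leaves unreadable from compound 3 to compound 4 in this assay. Compound 4 is accordingly expected to give 200000 nM, within a range of 100000 nM to 600000 nM, and most probably to be reported again only as a limit rather than a number.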

Compound 4, half-maximal inhibitory concentration: > 128000 nM
Compound 4 ended at the assay's limit; the forecaster's own chance of this, stated with the estimate: 90%; the middle value lies beyond the limit too.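

Compound 4 gives > 128000 nM in this assay and that is a limit, not a number. Compound 2 and compound 3 also stand at a limit, so no step can be read from compound 3 to compound 4 or from compound 2 to compound 4. The compounds shown leave open whether isobutyl in place of isopropyl changes inhibition at all, and which structures would give a readable value.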